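This account rests on a few compounds, and the source may have more. Where it says the series, first, only, none or still open, it means among the compounds named here.

Measured so far in a toxicity assay on Vero cells (Chlorocebus sabaeus) for cytotoxicity; on this read-out lower numbers stand for higher toxicity in this test and higher numbers for lower toxicity in this test:

compound 1, `COc1nc(-c2ccc(Cl)c(F)c2)ccc1[C@@H](c1ccccc1)[C@@](O)(CCN(C)C)c1cccc2ccccc12`, gives > 50 ug/mL, a limit of this assay.
compound 2, `COc1nc(-c2ccccc2Cl)ccc1[C@@H](c1ccccc1)[C@@](O)(CCN(C)C)c1cccc2ccccc12`, gives > 50 ug/mL, likewise a limit of this assay.

Both values sit at the limit described by the limit of > 50 ug/mL in this assay, at which 2 of the 2 values shown sit. Among the measured compounds shown here, compound 2 therefore stands at a limit only, with no number of its own; the single measured step, a step that the two limits leave unreadable from compound 1 to compound 2, is not readable in size or direction, since both ends are limits.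

Compound 3, `COc1nc(-c2ccc(Cl)cc2)ccc1[C@@H](c1ccccc1)[C@@](O)(CCN(C)C)c1cccc2ccccc12`, remains to be measured in this assay. The change from compound 2 is 4-chlorophenyl in place of 2-chlorophenyl on an aromatic carbon. For the measured compounds named here, the one measured step concerns another exchange of a chlorine-bearing phenyl group on the same aromatic carbon, but its size is unreadable, so it supplies no scale for the present step. What the data show is simply that both measured compounds reach the limit of this assay.

On that basis no shift beyond the scatter is expected, and compound 3 is most likely to be reported at the same limit. The estimate for compound 3 is 70 ug/mL, range 30 ug/mL to 150 ug/mL. This corresponds to an expected step that the limit leaves unreadable from compound 2 to compound 3 in this assay.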

Compound 3, half-maximal cytotoxic concentration: > 50 ug/mL
Compound 3 was reported as a limit; the forecaster's own chance of this, stated with the estimate: 80%; the middle value is on the limit's open side.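

Compound 3 sits at a limit of this assay, as do compound 1 and compound 2, so no step among the three can be read, in size or in direction: the limit of > 50 ug/mL in this assay, at which 3 of the 3 values shown sit.

The compounds shown leave open what cytotoxic concentration any of the three has in this assay, and whether exchanging the chlorine-bearing phenyl groups changes this read-out at all.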